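Swapping Benzyloxy for Chloro in a Cytotoxicity Series

The source may hold more compounds than are shown below. What is called first, only, known or untested is meant among the compounds shown, and "the series" means these compounds.

Compounds 1, 2 and 3 share one core and differ only in the aryl ring attached to the double-bonded chain carbon that also bears the carboxylic acid. Compound 1 `CC(=O)n1cc(/C=C(/C(=O)O)c2ccccc2)c2cc(OCc3ccccc3)ccc21` carries a plain phenyl there; in a functional assay on KB cells (Homo sapiens) for cytotoxicity, read by MTT assay, with a stated time of 72 h (on this read-out higher numbers stand for weaker inhibition and lower numbers for stronger inhibition), compound 1 gives 55500 nM. Compound 2 `COc1cc(/C(=C\c2cn(C(C)=O)c3ccc(OCc4ccccc4)cc23)C(=O)O)cc(OC)c1OC` carries a 3,4,5-trimethoxyphenyl instead. In this assay compound 2 reaches only a limit of the assay, > 100000 nM, rather than a number. The change an at least 1.8-fold higher number from compound 1 to compound 2 (0.25 log units; that floor lies within the scatter) is thus known only by its floor. Compound 3 `CC(=O)n1cc(/C=C(/C(=O)O)c2ccc(OCc3ccccc3)cc2)c2cc(OCc3ccccc3)ccc21` has a benzyloxy on the phenyl, and in this assay compound 3 gives 43000 nM; of the two real numbers shown it is the lower one, with compound 1 nearest, but the step of a 1.3-fold lower number from compound 1 to compound 3 (0.11 log units; within the scatter) lies within the scatter, so the two cannot truly be ordered.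

Compound 4 `CC(=O)n1cc(/C=C(/C(=O)O)c2ccc(Cl)cc2)c2cc(OCc3ccccc3)ccc21` has not yet been measured in this assay. It differs from compound 3 in one place: chloro in place of benzyloxy on an aromatic carbon. Going by the values given here, the only measured step touching that position, a 1.3-fold lower number from compound 1 to compound 3 (0.11 log units; within the scatter), shows that adding benzyloxy there or leaving hydrogen barely moves the number; replacing it with chloro is therefore expected to give no step beyond the scatter, a 1.0-fold higher number from compound 3 to compound 4 (0.02 log units; within the scatter). Compound 4 is estimated at 45000 nM, between 20000 nM and 100000 nM.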

Compound 4, half-maximal inhibitory concentration: > 100000 nM
Compound 4 ended at the assay's limit (the forecaster's own chance of this, stated with the estimate: 15%); middle value at least 2.2-fold (0.34 log units) from the limit.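

Compound 1 and compound 3 alone made this place on the phenyl ring look indifferent to what it carries, but in this assay the swap of benzyloxy for chloro gives an at least 2.3-fold higher number from compound 3 to compound 4 (0.36 log units; beyond the scatter), a step beyond the scatter. So the two groups are not interchangeable here, even though benzyloxy and hydrogen could not be told apart. Against hydrogen, chloro gives an at least 1.8-fold higher number from compound 1 to compound 4 (0.25 log units; that floor lies within the scatter), and that floor alone does not separate the two compounds, while the step between compound 2 and compound 4 cannot be read, as each value is only a limit of the assay: the limit of > 100000 nM in this assay, at which 2 of the 4 values shown sit.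

Going by these compounds, how far the true value of compound 4 lies past its limit stays unknown, so the full size of both readable steps stays open as well. On these data alone, it also stays open which part of benzyloxy, its oxygen or its carbon-only aromatic ring, goes with the lower number of compound 3, and a fluoro, an amine or a longer chain on the same aromatic carbon would give this position further points of comparison.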